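Swapping fluorine positions on a difluorobenzyl group

The source may report more compounds than this note shows. Statements on the series, on what has been measured and on what is new or still open speak of the compounds shown alone.

Three compounds have been measured in an assay on Sf21 cells for inhibition of high affinity nerve growth factor receptor (Homo sapiens), read by HTRF, with a stated time of 30 min, in the presence of a further agent that is not named here; on this read-out lower numbers stand for stronger inhibition and higher numbers for weaker inhibition:
compound 1 , `CC1(C)c2[nH]nc(NC(=O)c3ccc(F)cc3)c2CN1Cc1cccc(F)c1F`, gives 210 nM
compound 2 , `CC1(C)c2[nH]nc(NC(=O)c3ccc(F)cc3)c2CN1Cc1cc(F)cc(F)c1`, gives 350 nM
compound 3 , `CN1CCN(c2cccc(C(=O)Nc3n[nH]c4c3CN(Cc3cccc(F)c3F)C4(C)C)c2)CC1`, gives 210 nM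

The change from compound 1 to compound 2 is 3,5-difluorophenyl in place of 2,3-difluorophenyl on a saturated chain carbon bound to an amine nitrogen in a ring, and it gave a 1.7-fold higher number from compound 1 to compound 2 (0.22 log units; within the scatter). Compound 3 carries the same 2,3-difluorobenzyl group as compound 1 but a different core; how the two cores differ is not broken down here. Compound 3 and compound 1 stand level at the digits given, within the usual scatter.

Compound 4 , `CN1CCN(c2cccc(C(=O)Nc3n[nH]c4c3CN(Cc3cc(F)cc(F)c3)C4(C)C)c2)CC1`, has not yet been measured. It differs from compound 3 by 3,5-difluorophenyl in place of 2,3-difluorophenyl on a saturated chain carbon bound to an amine nitrogen in a ring, the same change at the same place as between compound 1 and compound 2. Because that earlier step gave a 1.7-fold higher number from compound 1 to compound 2 (0.22 log units; within the scatter), a step of similar size is expected here, a 1.7-fold higher number from compound 3 to compound 4 (0.22 log units; within the scatter). Compound 4 is therefore estimated at 350 nM in this assay, with a likely range from 150 nM to 800 nM.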

Compound 4, half-maximal inhibitory concentration: 150 nM
The estimate for compound 4 lay 2.3-fold (0.37 log units) above the measured number; measured number inside the range.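

In this assay, replacing the 2,3-difluorobenzyl group with the 3,5-difluorobenzyl group on the second core gave a 1.4-fold lower number from compound 3 to compound 4 (0.15 log units; within the scatter). The steps point in opposite directions, but the gap between them is no larger than repeat measurements could produce: the same change on two cores in this assay, a 1.7-fold higher number (0.22 log units; within the scatter) from compound 1 to compound 2 and a 1.4-fold lower number (0.15 log units; within the scatter) from compound 3 to compound 4, 2.3-fold (0.37 log units) apart, within the scatter of two such steps. On these two cores the change therefore has no effect that can be told from scatter, which shows that its effect is small on both but does not show that it is truly identical on both or that it would stay small on any other core.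

The compounds shown leave open what a plain benzyl, a chlorobenzyl or a pyridylmethyl group would do at this place. They also leave open whether such a swap would give steps large enough to compare clearly across the two cores.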